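The source may report more compounds than this note shows. Statements on the series, on what has been measured and on what is new or still open speak of the compounds shown alone.

Measured in a functional assay on KM12 cells (Homo sapiens) for cytotoxicity, read by sulforhodamine B assay, with a stated time of 48 h; on this read-out lower numbers stand for higher toxicity in this test and higher numbers for lower toxicity in this test:
- compound 1, `ClCc1ccccc1Cn1cnc2c(Cl)nc(Cl)nc21`: 5880 nM
- compound 2, `ClCc1cccc(Cn2cnc3nc(Cl)nc(Cl)c32)c1`: 74100 nM

Of the two, compound 1 carries the lower number, and compound 2 sits above it by a gap that is beyond the usual scatter. For the measured compounds named here, the two compounds do not differ in a single place, so no single-change step within the measured set is available, and nothing can be said about how any one exchange on the shared core moves the read-out.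

Compound 3, `Nc1nc(Cl)c2ncn(Cc3ccccc3CCl)c2n1`, has not yet been measured in this assay. It differs from compound 1 in one place: amino in place of chloro on an aromatic carbon. Going by the values given here, no measured pair shows an exchange of this kind, so the size of the step rests on no precedent. Given the lack of any guide, the expectation is a modest move toward a higher number, close to the edge of the scatter rather than clearly beyond it.

Compound 3 is accordingly expected to give about 12000 nM in this assay, within a range of 4000 nM to 40000 nM. The expected step is a 2.0-fold higher number from compound 1 to compound 3 (0.31 log units; beyond the scatter).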

Compound 3, concentration lethal to 50% of the cells: 97200 nM
Estimate against measurement, compound 3: 8.1-fold (0.91 log units) below, outside the stated range (above it).
By their numbers in this assay, from the lowest: compound 1; then compounds 2 and 3 (each within the scatter of the next).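

In this assay, the series now has its first single-change step: amino in place of chloro on an aromatic carbon, between two ring nitrogen atoms, gives a 17-fold higher number from compound 1 to compound 3 (1.22 log units; beyond the scatter). The step is large and beyond the scatter, so the read-out is not indifferent to what stands at this carbon, and within this pair the chloro form carries the lower number, which stands for higher toxicity in this test. No measurement on hand accounts for the size of the step, which stands here as an observation only.

Still open, on these data alone, is whether the step follows from the loss of chloro or from the arrival of amino, a question that a methoxy or methylamino group at the same carbon would help to separate. Also open, as far as these compounds go, is whether the exchange would move the read-out by a similar amount on the substitution pattern of compound 2, or at the chloro group that remains in compound 3.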